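The compounds below may be only part of what the source reports. "The series", "measured", "known", "first", "only" and "open" are said of these compounds alone.

Of the compounds shown here, three built on a shared core have been measured so far. Compound 1 `COc1cc2nc(N3CCN(C(=O)c4cccc5ccccc45)CC3)nc(N)c2cc1OC` in a functional assay on PC-3 cells (Homo sapiens) for inhibition (on this read-out higher numbers stand for weaker inhibition and lower numbers for stronger inhibition), gives 59000 nM. Compound 2 `COc1cc2nc(N3CCN(C(=O)c4ccc(C(C)(C)C)cc4)CC3)nc(N)c2cc1OC` gives 47000 nM in this assay, and compound 3 `COc1cc2nc(N3CCN(S(=O)(=O)c4ccc(Cl)cc4)CC3)nc(N)c2cc1OC` gives 23000 nM. Compound 3 therefore stands lowest of the three numbers, with compound 2 nearest and compound 1 furthest from it, both of those gaps lying beyond the scatter. For the measured compounds named here, the only pair of measured compounds that differ in one place is compound 1 and compound 2, where the step was a 1.3-fold lower number from compound 1 to compound 2 (0.10 log units; within the scatter), a change of the group on the carbonyl carbon.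

Compound 4 `COc1cc2nc(N3CCN(S(=O)(=O)c4ccc(I)cc4)CC3)nc(N)c2cc1OC` differs from compound 3 by iodo in place of chloro on an aromatic carbon. Going by the values given here, no measured step speaks to swapping one halogen for another on that ring, and the single step available concerns a different part of the molecule and stayed within the scatter. With nothing pointing either way, no step beyond the scatter is expected in this assay. Compound 4 is accordingly expected to give 23000 nM, in a range from 9000 nM to 60000 nM. The expected step is no change at the digits printed from compound 3 to compound 4 (within the scatter).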

Compound 4, half-maximal inhibitory concentration: 15000 nM
Compound 4: middle estimate off by 1.5-fold (0.19 log units), on the high side, and the stated range covers the measured number.
By their numbers in this assay, from the lowest: compounds 4 and 3 (each within the scatter of the next); then compounds 2 and 1 (each within the scatter of the next).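

In this assay, replacing the 4-chlorophenyl with a 4-iodophenyl gives a 1.5-fold lower number from compound 3 to compound 4 (0.19 log units; within the scatter), so this exchange of one halogen for another at the same ring position does not move the number beyond the scatter. The two halogens therefore cannot be told apart on this read-out, and this position accepts iodo as well as chloro. No supporting measurement is available to explain this result.

From the compounds shown here alone, both compounds carry a halogen at this position, so it remains open whether a group of another kind there, such as an amine, a carboxylic acid or a methoxy group, would shift the number beyond the scatter. Also open, going by these compounds, is how a plain phenyl, with only a hydrogen at this position, would compare with these two halogen-bearing compounds.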